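The compounds below may be only part of what the source reports. "The series", "measured", "known", "first", "only" and "open" are said of these compounds alone.

Measured so far in a functional assay on the whole organism with Rattus norvegicus as the target; on this read-out higher numbers stand for an effect only at larger amounts of compound and lower numbers for an effect already at smaller amounts:
compound 1 `COc1cc(N(C)C)c(Cl)cc1C(=O)NC1CCN(Cc2ccccc2)C1` gives 0.12 mg/kg
compound 2 `COc1cc(N)c(Cl)cc1C(=O)NC1CCN(C2CCCCC2)C1` gives 1.8 mg/kg

Compound 2 holds the higher of the two numbers, and compound 1 lies lower by more than the usual scatter. Compound 3 `COc1cc(N(C)C)c(Cl)cc1C(=O)NC1CCN(C2CCCCC2)C1` has dimethylamino in place of amino on an aromatic carbon of compound 2 and is still unmeasured. The counted change is dimethylamino in place of amino on an aromatic carbon and it sits ortho to a chloro group. For the measured compounds named here, no single-place step between measured compounds exists. Compound 1 at 0.12 mg/kg already carries dimethylamino but also differs from compound 2 in a second place, and the data do not separate the two changes. Expected in this assay is a moderate shift toward a lower number, with a 3.0-fold lower number from compound 2 to compound 3 (0.48 log units; beyond the scatter) as the estimated step. Compound 3 is estimated at 0.6 mg/kg with a range from 0.15 mg/kg to 2.2 mg/kg as the expected bounds.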

Compound 3, dose for half-maximal effect: 1 mg/kg
Estimate against measurement, compound 3: 1.7-fold (0.22 log units) below; measured number inside the range.
By their numbers in this assay, from the lowest: compound 1; then compounds 3 and 2 (each within the scatter of the next).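

In this assay, dimethylamino in place of amino on this aromatic carbon, ortho to a chloro group, gives a 1.8-fold lower number from compound 2 to compound 3 (0.26 log units; within the scatter), so on the cyclohexyl compounds this read-out does not tell the two groups apart. The other place now has a single-place step of its own: cyclohexyl in place of benzyl on the amine nitrogen in a ring gives an 8.3-fold higher number from compound 1 to compound 3 (0.92 log units; beyond the scatter), and this step, unlike the first, lies beyond the scatter. Nothing on hand gives a reason for either step.

Open, as far as these compounds go, is whether the amino and dimethylamino groups also match when benzyl sits on the ring nitrogen. Also open, from the compounds shown here alone, is how methylamino or diethylamino on the aromatic carbon, or phenethyl or cyclopentyl on the ring nitrogen, would read in this assay.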